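Methoxy in place of dimethylamino on the shared core

The source may report more compounds than this note shows. Statements on the series, on what has been measured and on what is new or still open speak of the compounds shown alone.

compound 1 `Cc1ccccc1/N=C1\NC(=O)/C(=C\c2ccc(N(C)C)cc2)S1`: > 100000 nM
compound 2 `CN(C)c1ccc(/C=C2/S/C(=N/c3ccc(Cl)cc3)NC2=O)cc1`: > 100000 nM

In an ADME assay on cells (Homo sapiens) for antiproliferative activity (a higher number here means a weaker inhibitor, a lower number a stronger inhibitor), compound 1 stands only at a limit of the assay, > 100000 nM, not at a number. Compound 2 likewise gives a limit, > 100000 nM. The step that the two limits leave unreadable from compound 1 to compound 2 is therefore unreadable, both values sitting at the limit of > 100000 nM in this assay, at which 2 of the 2 values shown sit. Compound 3 `COc1ccc(/C=C2/S/C(=N/c3ccccc3C)NC2=O)cc1` differs from compound 1 by methoxy in place of dimethylamino on an aromatic carbon. Going by the values given here, no measured step bears on this change, and no value shown gives a direction. Compound 3 is expected to stay at the limit, estimated at 100000 nM (range 30000 nM to 300000 nM). The step this estimate means, a number no higher from compound 1 to compound 3 (the limit leaves the size open), is expected to be none beyond the scatter.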

Compound 3, half-maximal inhibitory concentration: 195000 nM
For compound 3 the middle estimate is 2.0-fold (0.29 log units) below the measured one, and the stated range covers the measured number.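

No step from compound 1 to compound 3 can be read in this assay, because compound 1 gives only a limit: the limit of > 100000 nM in this assay, at which 2 of the 3 values shown sit.

From the compounds shown here alone, whether methoxy in place of dimethylamino on the shared core changes the activity at all remains open.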